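Pyridyl for nitrophenyl on the shared core

The source may report more compounds than this note shows. Statements on the series, on what has been measured and on what is new or still open speak of the compounds shown alone.

Measured compounds:
compound 1 `C(=N/Nc1nc2ccccc2nc1Cc1ccccc1)\c1ccccc1` — 81 nM
compound 2 `C/C(=N\Nc1nc2ccccc2nc1Cc1ccccc1)c1ccc([N+](=O)[O-])cc1` — 680 nM

Both compounds were tested in an assay on isolated protein for inhibition of Amine oxidase [flavin-containing] A (Homo sapiens), read by spectrophotometry; on this read-out higher numbers stand for weaker inhibition and lower numbers for stronger inhibition. Compound 2 gives 680 nM, the higher of the two numbers recorded; compound 1 gives 81 nM, and the gap between the two lies beyond the scatter of repeated measurements. Among the measured compounds shown here, the two compounds differ in more than one place, so no single step between them can be isolated.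

Compound 3 `C/C(=N\Nc1nc2ccccc2nc1Cc1ccccc1)c1ccccn1` is the next compound in the series and has not yet been measured. It differs from compound 2 in one place: pyridin-2-yl in place of 4-nitrophenyl on a carbon with a double bond to nitrogen.

For the measured compounds named here, no step for this exchange has been measured here. Going by the values given here, compound 2, which carries the 4-nitrophenyl group, stands at the weak end of the two numbers, and the only other compound, compound 1, carries a plain phenyl and lies well lower. On that footing a moderate move toward lower numbers is expected for compound 3, with the step from compound 2 estimated at a 2.3-fold lower number from compound 2 to compound 3 (0.36 log units; beyond the scatter). In this assay compound 3 is expected to give 300 nM, within a range of 80 nM to 1200 nM.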

Compound 3, half-maximal inhibitory concentration: 91 nM
Compound 3: middle estimate off by 3.3-fold (0.52 log units), on the high side; the range from low to high includes it.
By their numbers in this assay, from the lowest: compounds 1 and 3 (each within the scatter of the next); then compound 2.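

In this assay, pyridin-2-yl in place of 4-nitrophenyl on a carbon with a double bond to nitrogen gives a 7.5-fold lower number from compound 2 to compound 3 (0.87 log units; beyond the scatter), which shows that exchanging this one group can move the number beyond the scatter. The exchange of the group of 8 heavy atoms in compound 1 for the group of 9 heavy atoms in compound 3, on a nitrogen on an aromatic ring, gives a 1.1-fold higher number from compound 1 to compound 3 (0.05 log units; within the scatter), so this larger change stays within the scatter and compound 2 alone stands apart from the other two. No measurement bearing on the reason for either step is available.

With a single substituted phenyl in the series, the compounds shown cannot tell whether the higher number of compound 2 is specific to the 4-nitrophenyl group or would also appear with a phenyl ring carrying an amine, a methoxy group or a carboxylic acid. They also leave open how much depends on where the ring nitrogen sits, as pyridin-3-yl and pyridin-4-yl would show, and what a longer chain on the carbon with a double bond to nitrogen would do.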